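The compounds below may be only part of what the source reports. "The series", "measured", "known", "first", "only" and "open" are said of these compounds alone.

Measured compounds:
compound 1, `CN1CCC(c2ccc3c(c2)oc(=O)n3C(=O)NCCOCc2ccccc2)CC1`: 0.667 h
compound 2, `CCN1CCC(c2ccc3c(c2)oc(=O)n3C(=O)NCCCCc2ccccc2)CC1`: 0.833 h

Both numbers come from an ADME assay on a cell-free system (plasma, Mus musculus) for metabolic stability, read by LC-MS, tested at 2 uM; on this read-out lower numbers stand for a shorter-lived compound and higher numbers for a longer-lived compound. In this assay compound 1 gives 0.667 h and compound 2 gives 0.833 h; the two values lie within the usual scatter of each other, so no order between them is read. Compound 3, `CC(=O)N1CCC(c2ccc3c(c2)oc(=O)n3C(=O)NCCCCc2ccccc2)CC1`, differs from compound 2 in one place: acetyl in place of ethyl on an amine nitrogen in a ring. For the measured compounds named here, no step between measured compounds covers this change, so the series offers nothing to size it by. The expected step is a 1.2-fold higher number from compound 2 to compound 3 (0.08 log units; within the scatter), not beyond the scatter in either direction. Compound 3 is accordingly estimated at 1 h, with a range from 0.4 h to 2.5 h.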

Compound 3, half-life: 0.5 h
Estimate against measurement, compound 3: 2.0-fold (0.30 log units) above, within the range that was stated.
By their numbers in this assay, from the lowest: compounds 3, 1 and 2 (each within the scatter of the next).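

In this assay, acetyl in place of ethyl on an amine nitrogen in a ring gives a 1.7-fold lower number from compound 2 to compound 3 (0.22 log units; within the scatter). For the compounds shown here, this is the first size for this change, and it shows that this position takes the extra carbonyl oxygen without a step beyond the scatter. Nothing measured here bears on what lies behind this step.

As far as these compounds go, whether a free amine, a longer acyl chain or a carboxylic acid on this nitrogen would move the half-life beyond the scatter stays open. Also open, from the compounds shown here alone, is whether acetyl reads the same alongside the side chain of compound 1.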